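Ring size on the pyrazole nitrogen: from cyclopropyl to cyclopentyl

This account rests on a few compounds, and the source may have more. Where it says the series, first, only, none or still open, it means among the compounds named here.

Measured so far:
compound 1 `Cc1cc(NC(=O)Cn2nnc(-c3ccccc3)n2)n(C2CCC(C)(C)CC2)n1` — > 19%
compound 2 `Cc1cc(NC(=O)Cn2nnc(-c3ccccc3)n2)n(C2CC2)n1` — > 78%

Two compounds share one core and differ only in the group on an aromatic nitrogen. In an assay on HEK293 cells for activation of Kir3.1/Kir3.2 (Homo sapiens), read by thallium flux (on this read-out lower numbers stand for smaller maximal responses and higher numbers for larger maximal responses), compound 1 `Cc1cc(NC(=O)Cn2nnc(-c3ccccc3)n2)n(C2CCC(C)(C)CC2)n1` reports > 19%, which is a limit of the assay rather than a number. Compound 2 `Cc1cc(NC(=O)Cn2nnc(-c3ccccc3)n2)n(C2CC2)n1` reports > 78% in this assay, also a limit. Because both values sit at limits, the limit of > 19% in this assay, at which 1 of the 2 values shown sits, and (the limit of > 78% in this assay, at which 1 of the 2 values shown sits), the step that the two limits leave unreadable from compound 1 to compound 2 cannot be read in size. Compound 3 `Cc1cc(NC(=O)Cn2nnc(-c3ccccc3)n2)n(C2CCCC2)n1` carries cyclopentyl in place of cyclopropyl on an aromatic nitrogen. Within the data shown here, the only measured step that bears on this change is the unreadable one from compound 1 to compound 2, so its size gives no guide; compound 2 stands at the higher of the two limits. Compound 3 is estimated at 70% in this assay, within 30% to 110%, a step of a number at least 8 percentage points lower from compound 2 to compound 3 (that floor lies within the scatter) that is expected to fall within the scatter.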

Compound 3, largest response reached (Emax), in percent of the reference or control that the assay uses: 105%
Compound 3: middle estimate off by 35 percentage points, on the low side; the measured number falls inside the stated range.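

Neither the step from compound 1 to compound 3 nor the step from compound 2 to compound 3 can be read in size; the values of compound 1 and compound 2 are limits, not numbers. The compounds shown leave open how cyclopropyl, cyclopentyl and 4,4-dimethylcyclohexyl rank in this assay.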